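Swapping Butyl for Isopropyl on a Shared Core

A few compounds are considered here, and "the series" means these few. Any claim that something is new, unique, unknown or untested is made for them only; others in the source may bear on it.

Of the compounds shown here, three have been measured in a functional assay on HCC827 cells (Homo sapiens) for inhibition, read by fluorescence, with a stated time of 72 h; on this read-out lower numbers stand for stronger inhibition of growth and higher numbers for weaker inhibition of growth. Compound 1 `COc1cc(Nc2nc(N[C@H]3CC[C@H](N)CC3)nc3c2ncn3CCC(C)C)cc(OC)c1` gives 11200 nM. Compound 2 `CCCCCCn1cnc2c(Nc3cc(OC)cc(OC)c3)nc(N[C@H]3CC[C@H](N)CC3)nc21` gives 9100 nM, and compound 3 `CCCCCCn1cnc2c(Nc3cccc(Cl)c3)nc(N[C@H]3CC[C@H](N)CC3)nc21` gives 10200 nM. Compound 1 differs from compound 2 in a single place: isopropyl in place of butyl on a saturated chain carbon, two bonds along the chain from an aromatic nitrogen. That change moved the number by a 1.2-fold higher number from compound 2 to compound 1 (0.09 log units; within the scatter). Compound 3 differs from compound 2 in another place, on the shared core: 3-chlorophenyl in place of 3,5-dimethoxyphenyl on a nitrogen on an aromatic ring, a step of a 1.1-fold higher number from compound 2 to compound 3 (0.05 log units; within the scatter). All three numbers lie within the usual spread of repeated measurements of one another, so no order among them can be claimed, and none can be called stronger or weaker than the others.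

Compound 4 `CC(C)CCn1cnc2c(Nc3cccc(Cl)c3)nc(N[C@H]3CC[C@H](N)CC3)nc21` has not yet been measured. It stands to compound 3 as compound 1 stands to compound 2: isopropyl in place of butyl on a saturated chain carbon, two bonds along the chain from an aromatic nitrogen. The place of the change is described in the same words in both cases, so this is the same change, here made on the core that carries the 3-chlorophenyl group rather than the 3,5-dimethoxyphenyl group. Going by the values given here, the step is expected to be small, a 1.2-fold higher number from compound 3 to compound 4 (0.07 log units; within the scatter), because a 1.2-fold higher number from compound 2 to compound 1 (0.09 log units; within the scatter) is the only example of this change. That rests on a single pair, so the expectation is loose. For compound 4 the expected result is 12000 nM, with a likely range from 6000 nM to 24000 nM.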

Compound 4, concentration for 50% growth inhibition: 10300 nM
Compound 4: the middle estimate sits 1.2-fold (0.07 log units) above what was measured; the measured number falls inside the stated range.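

Made on the core that carries the 3-chlorophenyl group, isopropyl in place of butyl gives a 1.0-fold higher number from compound 3 to compound 4 (0.00 log units; within the scatter) in this assay and agrees with the step on the other core: the same change on two cores in this assay, a 1.2-fold higher number (0.09 log units; within the scatter) from compound 2 to compound 1 and a 1.0-fold higher number (0.00 log units; within the scatter) from compound 3 to compound 4, 1.2-fold (0.09 log units) apart, within the scatter of two such steps. The other change, 3-chlorophenyl in place of 3,5-dimethoxyphenyl, gives a 1.1-fold lower number from compound 1 to compound 4 (0.04 log units; within the scatter) on the core that carries isopropyl and also agrees with its earlier counterpart: the same change on two cores in this assay, a 1.1-fold higher number (0.05 log units; within the scatter) from compound 2 to compound 3 and a 1.1-fold lower number (0.04 log units; within the scatter) from compound 1 to compound 4, 1.2-fold (0.09 log units) apart, within the scatter of two such steps. Going by these compounds alone, each change therefore gives a matching result on both cores, but every one of these steps is within the scatter, so this shows only that neither change has a readable effect on these cores; it does not show that a larger step would carry over from one core to another in the same way.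

The compounds shown leave open whether any change at these two places can give a step beyond the scatter, for example a much longer chain or a chain ending in an amine or a carboxylic acid in place of the butyl. They also leave open what a nitrile or a trifluoromethyl group in place of the chlorine would do, and whether such a step would hold on both cores.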